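This account rests on a few compounds, and the source may have more. Where it says the series, first, only, none or still open, it means among the compounds named here.

Compound 1 `C[C@@H](Nc1c(C(=O)NCc2ccc(F)cc2)nc(Br)c2cccnc12)c1ccccc1`: > 20000 nM (a limit)
Compound 2 `O=C(NCc1ccc(F)cc1)c1nc(Br)c2cccnc2c1NCc1ccc(F)cc1`: > 20000 nM (a limit)

In a functional assay on HCT-116 cells (Homo sapiens) for cytotoxicity, read by MTT assay, with a stated time of 72 h (a higher number here means a weaker inhibitor, a lower number a stronger inhibitor), compound 2 stands at > 20000 nM as a limit, not a number. Compound 1 shares that place, as (the limit of > 20000 nM in this assay, at which 2 of the 2 values shown sit) shows. Compound 3 `N[C@H]1CC[C@H](Nc2c(C(=O)NCc3ccc(F)cc3)nc(Br)c3cccnc23)CC1` has 4-aminocyclohexyl in place of 4-fluorobenzyl on a nitrogen on an aromatic ring. Among the measured compounds shown here, the one measured step (a step that the two limits leave unreadable from compound 1 to compound 2) has no readable size, so it offers no size to carry over. The entering ring is non-aromatic, and a tentative move toward stronger inhibition in this assay is expected. The estimated change is an at least 2.5-fold lower number from compound 2 to compound 3 (0.39 log units; beyond the scatter) and remains uncertain. Compound 3 is estimated at 8000 nM with a range from 1500 nM to 30000 nM overall.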

Compound 3, half-maximal inhibitory concentration: 4000 nM
Compound 3: the middle estimate sits 2.0-fold (0.30 log units) above what was measured; the measured number falls inside the stated range.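

In this assay, among the compounds shown here, this position on a nitrogen on an aromatic ring gives a measured number for the first time once 4-aminocyclohexyl enters. Replacing 4-fluorobenzyl gives an at least 5.0-fold lower number from compound 2 to compound 3 (0.69 log units; beyond the scatter) and replacing 1-phenylethyl gives an at least 5.0-fold lower number from compound 1 to compound 3 (0.69 log units; beyond the scatter) as well, each beyond the usual scatter. On these data alone, the true size of both steps stays unknown because the two earlier compounds are limits, not numbers, and the step between them cannot be read: the limit of > 20000 nM in this assay, at which 2 of the 3 values shown sit.

The compounds shown do not separate the effect of the non-aromatic ring from that of its amine. A plain cyclohexyl or a hydroxyl-bearing cyclohexyl would tell these apart.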